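Compound 3 to a Piperidine: A Step From a Limit

The compounds below may be only part of what the source reports. "The series", "measured", "known", "first", "only" and "open" are said of these compounds alone.

In an ADME assay on MT4 cells (Homo sapiens) for cytotoxicity, read by MTT assay, with a stated time of 4 days (on this read-out lower numbers stand for higher toxicity in this test and higher numbers for lower toxicity in this test), compound 1 `Cc1c(C(C)c2c(F)cccc2F)nc(N(C)C)[nH]c1=O` gives > 17000 nM, which is a limit. Compound 2 `CCN(C)c1nc(C(C)c2c(F)cccc2F)c(C)c(=O)[nH]1` gives a number, 81000 nM. Compound 3 `CCCN(C)c1nc(C(C)c2c(F)cccc2F)c(C)c(=O)[nH]1` gives > 78000 nM, also a limit, so it stands without an exact number. Compound 4 `Cc1c(C(C)c2c(F)cccc2F)nc(N2CCCCC2)[nH]c1=O` changes the group on the shared core: piperidin-1-yl in place of methyl(propyl)amino on an aromatic carbon. For the measured compounds named here, three measured steps bear on this change, all on the open amine chain: a step that the limit leaves unreadable from compound 1 to compound 2, a step that the limit leaves unreadable from compound 2 to compound 3 and a step that the two limits leave unreadable from compound 1 to compound 3. None has a readable size, and none closes a chain into a ring. Only a small change is therefore expected in this assay, with no firm direction. The expected change is an at least 1.1-fold lower number from compound 3 to compound 4 (0.04 log units; that floor lies within the scatter), none beyond the scatter. Compound 4 is estimated at 70000 nM, with an expected range of 20000 nM to 200000 nM.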

Compound 4, half-maximal cytotoxic concentration: > 75000 nM
Compound 4: only a limit was reported (the forecaster's own chance of this, stated with the estimate: 50%); middle value at least 1.0-fold (0.02 log units) from the limit.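

Compound 4 gives > 75000 nM, which is a limit, so its steps from compound 1, compound 2 and compound 3 cannot be read. The compounds shown leave open whether piperidin-1-yl in place of an open amine chain changes this read-out at all.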